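Cytotoxicity of a methoxy analogue on the shared core

The source may report more compounds than this note shows. Statements on the series, on what has been measured and on what is new or still open speak of the compounds shown alone.

Compound 1 `N#Cc1ccc(Nc2nccc(Oc3ccc(-c4ccc(C#N)cc4)cc3C(F)(F)F)n2)cc1` was tested in a functional assay on MT4 cells (Homo sapiens) for cytotoxicity, read by MTT assay, with a stated time of 5 days; on this read-out lower numbers stand for higher toxicity in this test and higher numbers for lower toxicity in this test. In this assay compound 1 gives only a limit, > 273000 nM, and not a number. Among the three measured values, compound 1 therefore stands at a limit (the limit of > 273000 nM in this assay, at which 1 of the 3 values shown sits), and one further value shown is also a limit. Compound 2 `Cc1cc(C#N)ccc1-c1ccc(Oc2ccnc(Nc3ccc(C#N)cc3)n2)c(F)c1` likewise gives only a limit in this assay, > 296000 nM (the limit of > 296000 nM in this assay, at which 1 of the 3 values shown sits). Compound 3 `N#Cc1ccc(Nc2nccc(Oc3ccc(-c4ccc(C#N)cc4)c(Cl)c3)n2)cc1` gives a number in this assay, 31100 nM. No two of these compounds differ in only one place, so no measured step exists; the values show only that compound 3 sits at a number while compound 1 and compound 2 sit at limits.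

Compound 4 `COc1cc(-c2ccc(C#N)cc2)ccc1Oc1ccnc(Nc2ccc(C#N)cc2)n1` differs from compound 1 by methoxy in place of trifluoromethyl on an aromatic carbon. Among the measured compounds shown here, with no measured step to lean on, the expected step from compound 1 to compound 4 is estimated at an at least 1.3-fold lower number from compound 1 to compound 4 (0.13 log units; that floor lies within the scatter), which is no change beyond the scatter. Compound 4 is thus expected to give 200000 nM in this assay, within a range of 40000 nM to 400000 nM, with a fair chance that only a limit is reported.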

Compound 4, half-maximal cytotoxic concentration: > 298000 nM
Compound 4: a limit, no number; the forecaster's own chance of this, stated with the estimate: 55%; at least 1.4-fold (0.17 log units) between middle value and limit.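

In this assay compound 4 gives only a limit, > 298000 nM. Compound 1 also gives only a limit, > 273000 nM, so the step between compound 1 and compound 4 cannot be read. The compounds shown leave open whether methoxy in place of trifluoromethyl on an aromatic carbon changes this read-out at all.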